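The source may report more compounds than this note shows. Statements on the series, on what has been measured and on what is new or still open speak of the compounds shown alone.

The shared core appears in compound 1 `CC1CCN(C2CCN(S(=O)(=O)c3cccc(-c4ccc(F)cc4)c3)CC2)CC1` and compound 2 `CC1CCN(C2CCN(S(=O)(=O)c3ccc(F)cc3F)CC2)CC1`. In an ADME assay on HCT-116 cells (Homo sapiens) for cytotoxicity, read by CellTiter-Glo, with a stated time of 72 h (a higher number here means a weaker inhibitor, a lower number a stronger inhibitor), compound 1 reaches only a limit of the assay, > 5000 nM. In this assay compound 2 likewise stands at a limit, > 5000 nM. Both values thus sit at the limit of > 5000 nM in this assay, at which 2 of the 2 values shown sit. Compound 3 `CC1CCN(C2CCN(S(=O)(=O)c3ccc(Cl)nc3)CC2)CC1` has not been measured; it differs from compound 2 by 6-chloropyridin-3-yl in place of 2,4-difluorophenyl on a sulfonyl sulfur. For the measured compounds named here, with no measured step to lean on, the step that the limit leaves unreadable from compound 2 to compound 3 is expected to be none beyond the scatter in this assay. Compound 3 is estimated at 8000 nM, within a range of 3000 nM to 25000 nM.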

Compound 3, half-maximal inhibitory concentration: > 10000 nM
Compound 3 ended at the assay's limit; the forecaster's own chance of this, stated with the estimate: 85%; at least 1.2-fold (0.09 log units) between middle value and limit.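

For the compounds shown here, compound 2 and compound 3 both stand at limits of this assay, so no step between them can be read. The compounds shown leave open whether 6-chloropyridin-3-yl in place of 2,4-difluorophenyl shifts the value at all.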